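The source may hold more compounds than are shown below. What is called first, only, known or untested is meant among the compounds shown, and "the series" means these compounds.

Of the compounds shown here, two have so far been measured in a functional assay on CHO cells for agonist activity at sphingosine 1-phosphate receptor 5 (Homo sapiens), read by GTPgammaS binding; on this read-out lower numbers stand for an effect already at smaller amounts and higher numbers for an effect only at larger amounts of compound. Compound 1 `Cc1cc(CC(=O)O)ccc1-c1noc(-c2ccc(C3CCCCC3)cc2)n1` gives 4000 nM, while compound 2 `Cc1cc(CCC(=O)O)ccc1-c1noc(-c2ccc(OC(C)C)c(F)c2)n1` gives 530 nM. For the measured compounds named here, of these two numbers, the one for compound 2 is the lower, and the gap between them is wider than the usual scatter of repeated measurements, so compound 2 is the one that acts at the smaller amount of compound.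

Compound 3 `Cc1cc(-c2nc(-c3ccc(CCC(=O)O)cc3C)no2)ccc1OC(C)C` has not yet been measured in this assay. It differs from compound 2 in one place only: methyl in place of fluoro on an aromatic carbon. Everything else in the structure is kept. Going by the values given here, no pair of measured compounds differing in just this way is available, so the size of the step can only be guessed. A swap of one small group for another, with no change in rings, hydrogen-bond donors, hydrogen-bond acceptors or charge, is expected to move the number little, if at all, beyond the scatter.

The estimate for compound 3 in this assay is 400 nM, within a range from 130 nM to 1500 nM. This estimate means a step from compound 2 to compound 3 of a 1.3-fold lower number from compound 2 to compound 3 (0.12 log units; within the scatter), which is expected to stay within the scatter.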

Compound 3, half-maximal effective concentration: 210 nM
Compound 3: the middle estimate sits 1.9-fold (0.28 log units) above what was measured; measured number inside the range.
By their numbers in this assay, from the lowest: compound 3; then compound 2; then compound 1.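

In this assay, putting methyl in place of fluoro on an aromatic carbon, ortho to an isopropoxy group, gives a 2.5-fold lower number from compound 2 to compound 3 (0.40 log units; beyond the scatter), a modest step but one that clears the scatter. This position therefore responds to the exchange of one small group for another, even with one heavy atom leaving, one entering, and no change in rings, hydrogen-bond donors, hydrogen-bond acceptors or net charge. Compounds 1 and 2 differ in more than one place and could not single out any one position, and nothing measured here explains why the number falls.

Methyl and fluoro are the only two groups shown at this position, so it remains open whether chloro, ethyl or methoxy would give a lower number than methyl, a higher one, or one within the scatter. The step also comes from a single pair of compounds, leaving open whether the same exchange would change the number by a similar amount in a compound with a cyclohexyl group in place of the isopropoxy group.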